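The source may report more compounds than this note shows. Statements on the series, on what has been measured and on what is new or still open speak of the compounds shown alone.

The account opens with three measured compounds built on one shared core. Compound 1 `COc1ccc2c(=O)c(/C=C/C(=O)Nc3cccc(Cl)c3)coc2c1` carries a 3-chlorophenyl on the amide-type nitrogen; in a functional assay on Huh-7 cells (Homo sapiens) for inhibition, read by MTT assay, with a stated time of 48 h (a higher number here means a weaker inhibitor, a lower number a stronger inhibitor), compound 1 gives only a limit of the assay, > 100000 nM. Compound 2 `COc1ccc2c(=O)c(/C=C/C(=O)Nc3ccc(C)cc3)coc2c1` carries a 4-methylphenyl in its place, and in this assay compound 2 likewise gives only a limit, > 100000 nM. The step that the two limits leave unreadable from compound 1 to compound 2 therefore cannot be read. Compound 3 `Cc1ccc(CNC(=O)/C=C/c2coc3cc(O)ccc3c2=O)cc1`, with a hydroxy on the core, stands no differently: in this assay compound 3 gives only a limit, > 100000 nM. Within the data shown here, every value so far sits at the limit of > 100000 nM in this assay, at which 3 of the 3 values shown sit, so no measured step has a readable size.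

Compound 4 `COc1ccc2c(=O)c(/C=C/C(=O)NCc3ccc(C)cc3)coc2c1` differs from compound 3 by methyl in place of hydrogen on an oxygen on an aromatic ring. Among the measured compounds shown here, no measured step bears directly on this change, and the single step between measured compounds is unreadable, so the measured compounds point neither up nor down beyond the scatter. Compound 4 is accordingly expected to give 100000 nM, with a range from 30000 nM to 300000 nM. The step of a number no higher from compound 3 to compound 4 (the limit leaves the size open) is estimated to stay within the scatter, most likely ending in another limit.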

Compound 4, half-maximal inhibitory concentration: 14300 nM
The estimate for compound 4 lay 7.0-fold (0.84 log units) above the measured number, and the stated range ends above it.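

Hydroxy to methoxy on this oxygen on an aromatic ring gives the first readable step in this assay (an at least 6.9-fold lower number from compound 3 to compound 4 (0.84 log units; beyond the scatter)). On the amide-type nitrogen, 4-methylbenzyl likewise reads beyond the scatter, both in place of 4-methylphenyl (an at least 6.9-fold lower number from compound 2 to compound 4 (0.84 log units; beyond the scatter)) and in place of 3-chlorophenyl (an at least 6.9-fold lower number from compound 1 to compound 4 (0.84 log units; beyond the scatter)). Among the compounds shown, only compound 4 pairs methoxy with 4-methylbenzyl, and it alone gives a number rather than a limit: the limit of > 100000 nM in this assay, at which 3 of the 4 values shown sit.

Going by these compounds, the full size of all three steps stays open, since each is a bound set by a limit. Also open, on these data alone, is whether ethoxy on that oxygen, or 2-phenylethyl on the amide-type nitrogen, would lower the number further.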